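Trimming the side chain of compound 1 to reach compound 3

The source may hold more compounds than are shown below. What is called first, only, known or untested is meant among the compounds shown, and "the series" means these compounds.

Measured so far:
compound 1 `Cn1c([C@H](CC2CCCCC2)N2C(=O)CN(c3ccc(Oc4ccccc4)cc3)C2=O)nc2ccc(C(=O)O)cc21` — 24400 nM
compound 2 `COc1ccc(Oc2ccc(N3CC(=O)N([C@@H](CC(C)C)c4nc5ccc(C(=O)O)cc5n4C)C3=O)cc2)cc1` — 75300 nM

In an assay on isolated protein for inhibition of Bile acid receptor (Homo sapiens), read by TR-FRET and LanthaScreen (a higher number here means a weaker inhibitor, a lower number a stronger inhibitor), compound 1 gives 24400 nM, the lower of the two numbers; compound 2 gives 75300 nM, a gap beyond the usual scatter, though the two differ in more than one place, so the gap is not assigned to any single change.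

Compound 3 `C[C@@H](c1nc2ccc(C(=O)O)cc2n1C)N1C(=O)CN(c2ccc(Oc3ccccc3)cc2)C1=O` differs from compound 1 by hydrogen in place of cyclohexyl on a saturated chain carbon, two bonds along the chain from an amide-type nitrogen in a ring and an aromatic carbon. Within the data shown here, no measured pair isolates this change. A weakening is expected: the step from compound 1 to compound 3 is estimated at a 2.9-fold higher number from compound 1 to compound 3 (0.46 log units; beyond the scatter). Compound 3 is expected near 70000 nM, with a likely range of 20000 nM to 250000 nM.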

Compound 3, half-maximal inhibitory concentration: 10400 nM
Compound 3: the middle estimate sits 6.7-fold (0.83 log units) above what was measured; measured number outside the range, below it.
By their numbers in this assay, from the lowest: compound 3; then compound 1; then compound 2.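

In this assay, among these compounds, the change from cyclohexylmethyl to methyl gives a 2.3-fold lower number from compound 1 to compound 3 (0.37 log units; beyond the scatter) and is the first single-place comparison. On this pair, the cyclohexyl is not required at this saturated chain carbon, and its removal strengthens inhibition modestly. Nothing measured here explains the shift. Going by these compounds, whether an ethyl or a hydroxymethyl in place of the methyl of compound 3 would lower the number further remains open. Also open, on these data alone, is whether the same change would have a similar effect on compound 2, whose side chain and remaining structure both differ from those of compound 1.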